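A few compounds are considered here, and "the series" means these few. Any claim that something is new, unique, unknown or untested is made for them only; others in the source may bear on it.

Measured compounds in the series:
- compound 1, `O=c1ccn([C@@H]2O[C@H](CO)C[C@H]2O)c(=O)[nH]1`; in a functional assay on CCRF-CEM cells (Homo sapiens) (on this read-out higher numbers stand for an effect only at larger amounts of compound and lower numbers for an effect already at smaller amounts), compound 1 gives only a limit, > 100 uM.
- compound 2, `CC(=O)OC[C@@H]1C[C@H](OC(C)=O)[C@H](n2ccc(N)nc2=O)O1`; compound 2 gives 1 uM.
- compound 3, `CC(=O)O[C@H]1C[C@@H](CO)O[C@H]1n1ccc(N)nc1=O`; compound 3 gives 3 uM.

Compound 3 holds the higher of the two numbers obtained so far. Its nearest neighbour is compound 2, and the move between them is a 3.0-fold higher number from compound 2 to compound 3 (0.48 log units; beyond the scatter), the change being hydrogen in place of acetyl on an oxygen on a saturated carbon. For compound 1 only a limit is known (the limit of > 100 uM in this assay, at which 1 of the 3 values shown sits), so it cannot be ranked against the other two.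

Compound 4, `CC(=O)Nc1ccn([C@@H]2O[C@H](CO)C[C@@H]2OC(C)=O)c(=O)n1`, is not yet measured. Relative to compound 3 the difference is acetyl in place of hydrogen on a nitrogen on an aromatic ring, that is, amino to acetamido. Among the measured compounds shown here, none of the measured steps touches this nitrogen: the single known step in this assay concerns an acetyl on an oxygen of the sugar, where the acetyl form sat at the lower number, and it is modest in size. That step therefore offers no direct guide, only a sense that acetyl exchanges in this series have moved the number by modest amounts.

On that basis the expected step from compound 3 to compound 4 in this assay is a 1.7-fold higher number from compound 3 to compound 4 (0.22 log units; within the scatter), with no confident direction. Compound 4 is estimated at 5 uM, in the range 1 uM to 30 uM.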

Compound 4, concentration for half-maximal effect: > 100 uM
Compound 4: only a limit was reported; the forecaster's own chance of this, stated with the estimate: 10%; middle value at least 20-fold (1.30 log units) from the limit.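

In this assay the nitrogen on an aromatic ring proves far more sensitive to acetyl than anything seen earlier in the series, with amino to acetamido giving an at least 33-fold higher number from compound 3 to compound 4 (1.52 log units; beyond the scatter) in this single pair. Compound 4 gives only a limit, and it is now one of two such results in the set: the limit of > 100 uM in this assay, at which 2 of the 4 values shown sit. Among the compounds shown here, the only earlier acetyl exchange, the removal of acetyl from an oxygen on a saturated carbon, gave a 3.0-fold higher number from compound 2 to compound 3 (0.48 log units; beyond the scatter) and stayed modest, so in these compounds the same group counts for much more on this nitrogen than on that oxygen.

Still open, as far as these compounds go, is whether this large step belongs to acetyl in particular or to any substituent on the amino nitrogen, a question that a methyl, a formyl or a longer acyl chain such as butanoyl in the same place would address. Also open is whether the acetamido form behaves the same way when the sugar oxygens carry a different pattern of acetyl and hydrogen, since only one such pattern is shown with it.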